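The compounds below may be only part of what the source reports. "The series", "measured", "known", "first", "only" and "open" are said of these compounds alone.

Measured compounds in a functional assay on CHO cells for positive allosteric modulation of muscarinic acetylcholine receptor M5 (Homo sapiens), read by calcium flux; on this read-out higher numbers stand for larger maximal responses and lower numbers for smaller maximal responses:
compound 1 `CCN(Cc1ccccc1)C(=O)C1CCN(S(=O)(=O)c2ccc(OC)c(OC)c2)CC1`: 57%
compound 2 `CCN(Cc1ccccc1)C(=O)C1CCN(S(=O)(=O)c2ccc3cn[nH]c3c2)CC1`: 86%

Within the data shown here, compound 2 holds the higher of the two numbers, the only measured step being a number 29 percentage points higher from compound 1 to compound 2 (beyond the scatter); compound 1 is its nearest neighbour. That step concerns the group on the sulfonyl sulfur alone and leaves the amide side of the shared core untouched.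

Compound 3 `CCN(Cc1cccc(F)c1)C(=O)C1CCN(S(=O)(=O)c2ccc3cn[nH]c3c2)CC1` is the next member to be measured. It differs from compound 2 by fluoro in place of hydrogen on an aromatic carbon, the amide side now carrying a 3-fluorobenzyl group where compound 2 carries benzyl.

Among the measured compounds shown here, no measured step bears on this change: the one step recorded lies on the other end of the shared core, and nothing among the measured compounds varies the benzyl group. The expectation therefore rests on compound 2 alone, and with no guide for the benzyl position the expected step is none beyond the scatter, a number 2 percentage points lower from compound 2 to compound 3 (within the scatter). The estimate for compound 3 in this assay is accordingly 84%, within a range of 66% to 100%, the width of that range reflecting the absence of any comparable step.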

Compound 3, largest response reached (reported as percent of maximum), in percent of the reference or control that the assay uses: 89%
For compound 3 the middle estimate is 5 percentage points below the measured one, and the stated range covers the measured number.
By their numbers in this assay, from the lowest: compound 1; then compounds 2 and 3 (each within the scatter of the next).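

The benzyl group on the amide side, untouched by the earlier step, now has its first measured change. In this assay, fluoro in place of hydrogen on an aromatic carbon gives a number 3 percentage points higher from compound 2 to compound 3 (within the scatter), so the change from benzyl to 3-fluorobenzyl leaves the maximal response indistinguishable from that of the parent, and the high level seen with the 1H-indazol-6-yl group on the sulfonyl sulfur holds with this substitution on the amide side. No measurement bears on why this single fluorine leaves the read-out within the scatter.

This one pair cannot show whether the benzyl ring is generally permissive, since a chloro, methoxy, trifluoromethyl or aminomethyl group at the same carbon, or fluoro on another carbon of the ring, could behave differently. Also open, on these data alone, are the ethyl group on the amide nitrogen, where a longer chain such as n-butyl would test that side further, and whether 3-fluorobenzyl gives the same result with the 3,4-dimethoxyphenyl group of compound 1 on the sulfonyl sulfur.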